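The source may hold more compounds than are shown below. What is called first, only, known or untested is meant among the compounds shown, and "the series" means these compounds.

In an assay on membranes from lung (Cavia porcellus) for binding affinity to cysteinyl leukotriene receptor (Homo sapiens) (on this read-out higher numbers stand for weaker inhibition and lower numbers for stronger inhibition), compound 1 `c1ccc2nc(COc3ccc(OCCCc4nnn[nH]4)cc3)ccc2c1` gives 69 nM, and compound 2 `CCCC(CCC(=O)O)Cc1cccc(OCc2ccc3ccccc3n2)c1` gives 50 nM. Compound 2 thus stands alongside compound 1 on this assay, the two numbers lying within the scatter of each other, so no ordering between them can be claimed. The next step leads to compound 3 `CC(CCCc1cccc(OCc2ccc3ccccc3n2)c1)C(=O)O`, which differs from compound 2 in one place: 3-carboxybutyl in place of 1-(2-carboxyethyl)butyl on a saturated chain carbon bound to an aromatic carbon. For the measured compounds named here, no measured pair spans this change, so the expectation rests on compound 2 alone; a modest weakening, at most a little beyond the scatter, is expected, as the step of a 2.4-fold higher number from compound 2 to compound 3 (0.38 log units; beyond the scatter) expresses. Compound 3 is accordingly estimated at 120 nM, with a plausible range from 40 nM to 400 nM.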

Compound 3, inhibition constant: 85 nM
Compound 3: the middle estimate sits 1.4-fold (0.15 log units) above what was measured, and the stated range covers the measured number.
By their numbers in this assay, from the lowest: compounds 2, 1 and 3 (each within the scatter of the next).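

In this assay the exchange of 1-(2-carboxyethyl)butyl for 3-carboxybutyl on a saturated chain carbon bound to an aromatic carbon gives a 1.7-fold higher number from compound 2 to compound 3 (0.23 log units; within the scatter) and so shows that this position accepts the smaller group, with 7 heavy atoms instead of 9, without a change beyond the scatter. Both groups keep the carboxy function, so only the carbon chain differs here. Nothing measured here offers an explanation for this result. Still open, as far as these compounds go, is whether a shorter chain would behave the same, and whether an amide or an amine could stand in place of the carboxylic acid at this position.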